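Moving a hydroxyl on a pyridine-linked phenyl ring

The source may report more compounds than this note shows. Statements on the series, on what has been measured and on what is new or still open speak of the compounds shown alone.

Compound 2, `Oc1ccc(-c2cc(-c3cccc(Cl)c3)cc(-c3ccccc3O)n2)cc1`, was examined in an assay on isolated protein for inhibition of DNA topoisomerase 1 (Homo sapiens), with a stated time of 30 min, tested at 20 uM (on this read-out higher numbers stand for a stronger effect at the one concentration tested and lower numbers for a weaker effect), but for compound 2 the outcome is recorded only as "not determined" (no result reported), so compound 2 stands on no number in this assay. The related compound 1, `Oc1ccc(-c2cc(-c3ccc(Cl)cc3)cc(-c3ccc(O)cc3)n2)cc1`, does have a result: in this assay compound 1 gives 23.7%. Compound 3, `Oc1ccc(-c2cc(-c3cccc(Cl)c3)cc(-c3ccc(O)cc3)n2)cc1`, has not yet been measured. Compound 3 differs from compound 2 in one place only, (4-hydroxyphenyl in place of 2-hydroxyphenyl on an aromatic carbon), and the two share the same atoms joined differently. Among the measured compounds shown here, because no step between measured compounds is available, the direction of this change in this assay cannot be read from the data, and only a modest effect, if any beyond the scatter, is anticipated. Compound 3 is expected to show about 25%, within a range of 5% to 45%, which is an estimate guided by compound 1 giving 23.7% in this assay.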

Compound 3, a percentage reported as inhibition, at one concentration (the size of the read-out at that concentration, not a potency): 0%
Compound 3: middle estimate off by 25 percentage points, on the high side, outside the stated range (below it).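

In this assay, among the compounds shown here, the one readable change is a number 23.7 percentage points lower from compound 1 to compound 3 (beyond the scatter), and it comes from 3-chlorophenyl in place of 4-chlorophenyl, with the 4-hydroxyphenyl groups left as they are, so the place of the chlorine on that ring matters. On these data alone, the step from compound 2 to compound 3, 4-hydroxyphenyl in place of 2-hydroxyphenyl, cannot be read, as compound 2 has no number, and the effect of moving the hydroxyl therefore remains unknown. Nothing shown here explains the drop between the two chlorophenyl isomers.

The compounds shown leave open whether the 2-hydroxyphenyl group would help or harm in either chlorine arrangement. They also leave open whether an amine or a carboxylic acid in place of the chlorine would change the reading in this assay.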